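This account rests on a few compounds, and the source may have more. Where it says the series, first, only, none or still open, it means among the compounds named here.

Of the compounds shown here, two of the shared core have been measured in a functional assay on BT-549 cells (Homo sapiens) for inhibition, read by sulforhodamine B assay, with a stated time of 48 h; on this read-out lower numbers stand for stronger inhibition of growth and higher numbers for weaker inhibition of growth. Compound 1 `COc1cc(-c2nn(-c3cccc(NC(=O)Nc4cc(C(F)(F)F)cc(C(F)(F)F)c4)c3)cc2-c2ccncc2)ccc1Cl` gives 1210 nM. For the measured compounds named here, compound 2 `COc1cc(-c2nn(-c3cccc(NC(=O)c4cccc(C(F)(F)F)c4)c3)cc2-c2ccncc2)ccc1Cl` gives 2870 nM, the higher of the two numbers, with compound 1 as its only neighbour beyond the scatter.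

Compound 3 `COc1cc(-c2nn(-c3cccc(NC(=O)Nc4cccc(C(F)(F)F)c4)c3)cc2-c2ccncc2)ccc1Cl` has not been measured. It differs from compound 2 in one place: (3-(trifluoromethyl)phenyl)amino in place of 3-(trifluoromethyl)phenyl on a carbonyl carbon. The carbonyl is thereby flanked by two amide-type nitrogens, as in compound 1, while the trifluoromethyl substitution on the outer ring stays as in compound 2.

Going by the values given here, no directly comparable step is known. Compound 1, which also carries the (3-(trifluoromethyl)phenyl)amino-type arrangement on the carbonyl, gives 1210 nM, so a move toward a lower number is expected for compound 3, of modest size, estimated as a 1.6-fold lower number from compound 2 to compound 3 (0.20 log units; within the scatter). The value for compound 3 in this assay is estimated at 1800 nM, with a range from 700 nM to 4500 nM.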

Compound 3, concentration for 50% growth inhibition: 1250 nM
Beside the measured number, compound 3's estimate is 1.4-fold (0.16 log units) above it; the measured number falls inside the stated range.
By their numbers in this assay, from the lowest: compounds 1 and 3 (each within the scatter of the next); then compound 2.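

In this assay, for the compounds shown here, (3-(trifluoromethyl)phenyl)amino in place of 3-(trifluoromethyl)phenyl on a carbonyl carbon gives a 2.3-fold lower number from compound 2 to compound 3 (0.36 log units; beyond the scatter) as the first reading of this change alone, with the rest of the molecule held constant. Hydrogen in place of trifluoromethyl on an aromatic carbon gives a 1.0-fold higher number from compound 1 to compound 3 (0.01 log units; within the scatter) in the same assay, so of the two places in which compound 1 and compound 2 differ, only the one at the carbonyl carbon shows a step beyond the scatter. Nothing at hand accounts for the step at the carbonyl carbon.

On these data alone, whether that step depends on the nitrogen itself or on its hydrogen stays open, and a methylene or a methylamino link at the same place would separate the two. Also open, as far as these compounds go, is whether the step holds when the trifluoromethyl is replaced by a carboxylic acid or an amine.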